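Removing a 3-Methoxyphenyl From an Amide Nitrogen

The compounds below may be only part of what the source reports. "The series", "measured", "known", "first", "only" and "open" are said of these compounds alone.

Measured so far:
compound 1 `O=C1COc2ccc(-c3cccc(NS(=O)(=O)c4ccc(F)cc4)c3)cc2N1`: 18300 nM
compound 2 `COc1cccc(N2C(=O)COc3ccc(-c4cccc(NS(=O)(=O)c5ccc(F)cc5)c4)cc32)c1`: > 40000 nM, a limit of the assay
compound 3 `COc1cccc(N2C(=O)COc3ccc(-c4ccc(O)cc4)cc32)c1`: > 40000 nM, a limit of the assay

In a functional assay on MCF7 cells (Homo sapiens) for antiproliferative activity, read by MTT assay, with a stated time of 72 h (on this read-out lower numbers stand for stronger inhibition and higher numbers for weaker inhibition), compound 1 gives 18300 nM. For compound 2 only a limit is known, > 40000 nM. For compound 3 likewise only a limit is known, > 40000 nM; both sit at the limit of > 40000 nM in this assay, at which 2 of the 3 values shown sit. Compound 2 and compound 1 differ in one place, (hydrogen in place of 3-methoxyphenyl on an amide-type nitrogen in a ring), and this brings an at least 2.1-fold lower number from compound 2 to compound 1 (0.33 log units; beyond the scatter). Compound 4 `O=C1COc2ccc(-c3ccc(O)cc3)cc2N1` is not yet measured; it arises from compound 3 by the same change at the same place, (hydrogen in place of 3-methoxyphenyl on an amide-type nitrogen in a ring). How the cores of compound 2 and compound 3 differ is not broken down here. Given an at least 2.1-fold lower number from compound 2 to compound 1 (0.33 log units; beyond the scatter) and compound 3 standing at the limit of > 40000 nM in this assay, at which 2 of the 3 values shown sit, the step from compound 3 to compound 4 is expected to be of a similar size, an at least 1.6-fold lower number from compound 3 to compound 4 (0.20 log units; that floor lies within the scatter). Compound 4 is estimated at 25000 nM, likely between 8000 nM and 80000 nM, with a real chance that only a limit is reported.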

Compound 4, half-maximal inhibitory concentration: > 40000 nM
Compound 4 ended at the assay's limit; the forecaster's own chance of this, stated with the estimate: 45%; middle value at least 1.6-fold (0.20 log units) from the limit.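

The step from compound 3 to compound 4 cannot be read, since both compounds end at the same limit of the assay: the limit of > 40000 nM in this assay, at which 3 of the 4 values shown sit.

The compounds shown leave open whether hydrogen in place of 3-methoxyphenyl on the amide-type nitrogen changes activity at all on the core of compound 3.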